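The source may report more compounds than this note shows. Statements on the series, on what has been measured and on what is new or still open speak of the compounds shown alone.

In a functional assay on PC-3 cells (Homo sapiens) for inhibition, read by MTT assay, with a stated time of 48 h (on this read-out higher numbers stand for weaker inhibition and lower numbers for stronger inhibition), compound 1 (`COc1ccc(-n2c(SCc3ccccc3)nnc2-c2cc(OC)c(OC)c(OC)c2)cc1`) gives 34100 nM. Compound 2 (`COc1ccc(C(=O)CSc2nnc(-c3cc(OC)c(OC)c(OC)c3)n2-c2ccc(OC)cc2)cc1`) reads > 60000 nM, which is a limit of the assay and not a number. Compound 3 (`COc1ccc(-n2c(SCC(=O)c3ccc(OC)c(O)c3)nnc2-c2cc(OC)c(OC)c(OC)c2)cc1`) reads > 60000 nM, which is also a limit. On these data alone, compound 3 therefore stands at the limit of > 60000 nM in this assay, at which 2 of the 3 values shown sit, so its true value is unknown.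

Compound 4 (`COc1ccc(NC(=O)CSc2nnc(-c3cc(OC)c(OC)c(OC)c3)n2-c2ccc(OC)cc2)cc1`) differs from compound 3 in one place: (4-methoxyphenyl)amino in place of 3-hydroxy-4-methoxyphenyl on a carbonyl carbon. In words, (4-methoxyphenyl)amino takes the place of 3-hydroxy-4-methoxyphenyl on a carbonyl carbon.

Among the compounds with values here, no measured step makes this exact exchange. The closest evidence comes from changes at the same side of the molecule. These are an at least 1.7-fold higher number from compound 1 to compound 2 (0.24 log units; that floor lies within the scatter) and an at least 1.7-fold higher number from compound 1 to compound 3 (0.24 log units; that floor lies within the scatter), and both have floors within the scatter. Adding hydroxy gives a step that the two limits leave unreadable from compound 2 to compound 3, so its effect cannot be judged.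

With no measured support for a shift, no change beyond the scatter is expected in this assay, and the estimated step is a number no higher from compound 3 to compound 4 (the limit leaves the size open). Compound 4 is expected at about 60000 nM, with an estimated range of 20000 nM to 120000 nM.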

Compound 4, half-maximal inhibitory concentration: 25800 nM
Beside the measured number, compound 4's estimate is 2.3-fold (0.37 log units) above it; the measured number falls inside the stated range.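

In this assay, (4-methoxyphenyl)amino on the carbonyl carbon gives an at least 2.3-fold lower number from compound 3 to compound 4 (0.36 log units; beyond the scatter), and the same group gives an at least 2.3-fold lower number from compound 2 to compound 4 (0.36 log units; beyond the scatter). Compound 2 and compound 4 both carry a 4-methoxyphenyl group, so this second step shows that adding the amino link to the carbonyl is enough to bring the reading down from the limit to a measurable number. The chain of compound 4 nevertheless gives no clear gain over the plain phenyl chain, with a 1.3-fold lower number from compound 1 to compound 4 (0.12 log units; within the scatter), so these two compounds cannot be told apart.

On these data alone, how an ester oxygen or a methylated amine would read in place of this amino link stays open. The full size of the first two steps also stays open, since compound 2 and compound 3 each read only as a limit: the limit of > 60000 nM in this assay, at which 2 of the 4 values shown sit.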